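The compounds below may be only part of what the source reports. "The series", "measured", "known", "first", "only" and "open" are said of these compounds alone.

Going by the values given here, compound 1 (`O=C1c2ccc(Cl)cc2C(C2CC2)N1c1cccnc1`) is one of three compounds measured in an assay on cells for inhibition of cytochrome P450 11B2, mitochondrial (Homo sapiens), read by HTRF; a lower number here means a stronger inhibitor, a higher number a weaker inhibitor. Here compound 1 gives 161 nM, the highest of the three numbers. Compound 2 (`CC1(C)c2cc(Cl)ccc2C(=O)N1c1cccnc1`) gives 108 nM, and the gap to compound 1 lies within the usual scatter of repeated measurements, so the two cannot be told apart. Compound 3 (`Cc1cccnc1C(=O)NCc1cncc(N2C(=O)c3ccc(Cl)cc3C2(C)C)c1`) gives 9 nM, a gap to compound 1 that lies well beyond the scatter. Among the compounds with values here, no pair of these measured compounds differs in only one place, so the three values do not isolate any single structural step.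

Compound 4 (`O=C1c2ccc(Cl)cc2CN1c1cccnc1`) has not yet been measured in this assay. It differs from compound 1 in one place: hydrogen in place of cyclopropyl on a saturated ring carbon. Within the data shown here, this change has no counterpart among the measured compounds, so the expectation rests on the change itself and on the value of compound 1, which is 161 nM. The number for compound 4 is expected to rise by a step of a 2.8-fold higher number from compound 1 to compound 4 (0.45 log units; beyond the scatter), beyond the scatter but not by a large amount. For compound 4 the expected value in this assay is 450 nM, with a range from 150 nM to 1400 nM.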

Compound 4, half-maximal inhibitory concentration: 179 nM
Beside the measured number, compound 4's estimate is 2.5-fold (0.40 log units) above it; low and high end bracket the measured number.
By their numbers in this assay, from the lowest: compound 3; then compounds 2, 1 and 4 (each within the scatter of the next).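

In this assay, hydrogen in place of cyclopropyl on this saturated ring carbon gives a 1.1-fold higher number from compound 1 to compound 4 (0.05 log units; within the scatter), so the two compounds cannot be told apart. Going by these compounds alone, this is the first step that changes only one place, and it shows that, on the core of compound 1, the cyclopropyl group can be removed from this position with no change that the measurement can detect: the ring carbon bearing only hydrogen serves as well in this assay as the one bearing the three-membered ring. No measured information explains why this swap leaves the number within the scatter.

Going by these compounds, only two substituents have been compared one-to-one at this carbon, so it remains open whether the position accepts any group without consequence, or whether a longer chain such as butyl, an amine or a carboxylic acid placed here would shift the number beyond the scatter. On these data alone, it is also open whether the same swap would be equally silent on a compound carrying an additional amide side chain on the pyridin-3-yl group.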